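Benzofuran hydrazone series: fluorophenyl replacement for the phenol

The source may report more compounds than this note shows. Statements on the series, on what has been measured and on what is new or still open speak of the compounds shown alone.

Three compounds carry the shared core of compound 2 `Cc1ccc(O)c(/C=N\NC(=O)c2oc3cccc(O)c3c2C)c1` with different aryl groups on the imine carbon. In a functional assay on PC-3 cells (Homo sapiens) for inhibition (on this read-out higher numbers stand for weaker inhibition and lower numbers for stronger inhibition), compound 2 gives 7350 nM. Compound 3 `Cc1c(C(=O)N/N=C\c2cc(Cl)cc(Cl)c2O)oc2cccc(O)c12` gives 9590 nM in this assay, and the two numbers lie within the usual scatter of each other, so no order between compound 2 and compound 3 can be read. Compound 1 `Cc1c(C(=O)N/N=C\c2ccc(O)c(O)c2O)oc2cccc(O)c12` is reported only as a limit in this assay, >= 40000 nM, which is the limit of >= 40000 nM in this assay, at which 1 of the 3 values shown sits. Only these two numbers and one limit are available for the core, and no two of the measured compounds differ in one place.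

Compound 4 `Cc1c(C(=O)N/N=C\c2ccccc2F)oc2cccc(O)c12` is not yet measured. It differs from compound 2 by 2-fluorophenyl in place of 2-hydroxy-5-methylphenyl on a carbon with a double bond to nitrogen. The entering group carries 0 hydrogen-bond donors and 0 hydrogen-bond acceptors where the leaving group carried one of each. Among the compounds with values here, with no measured step of this kind to lean on, the expectation is a modest loss within or just beyond the scatter, a 1.6-fold higher number from compound 2 to compound 4 (0.21 log units; within the scatter). Compound 4 is therefore estimated at 12000 nM in this assay, with a range from 4000 nM to 40000 nM.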

Compound 4, half-maximal inhibitory concentration: >= 40000 nM
Compound 4: a limit, no number; the forecaster's own chance of this, stated with the estimate: 25%; middle value at least 3.3-fold (0.52 log units) from the limit.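

In this assay, within the data shown here, this is the first step that differs in one place, and it shows that the group on a carbon with a double bond to nitrogen is not freely exchangeable: 2-fluorophenyl in place of 2-hydroxy-5-methylphenyl gives an at least 5.4-fold higher number from compound 2 to compound 4 (0.73 log units; beyond the scatter). As far as these compounds go, the reading for compound 4 is a limit and not a number, so the step fixes only a minimum size, and the true size stays unknown. The result adds a second compound at the limit of the assay: the limit of >= 40000 nM in this assay, at which 2 of the 4 values shown sit.

The step removes the hydroxy and methyl groups and introduces fluorine all at once, so it does not show which of these changes accounts for the loss. From the compounds shown here alone, whether a phenyl carrying an amine or a methoxy group at this place would give a measurable value remains open.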